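A few compounds are considered here, and "the series" means these few. Any claim that something is new, unique, unknown or untested is made for them only; others in the source may bear on it.

Measured compounds:
compound 1, `CCCCCNC(=O)NS(=O)(=O)c1cc(C#N)ccc1Oc1ccccc1C`, giving 2240 nM
compound 2, `CC(C)(C)NC(=O)NS(=O)(=O)c1cc(C#N)ccc1Oc1ccc(F)cc1`, giving 4350 nM

Two ureas sharing the same sulfonyl-benzonitrile core were tested in a functional assay on HEK293 cells for antagonist activity at thromboxane A2 receptor (Homo sapiens), read by fluorescence and calcium flux; a lower number here means a stronger inhibitor, a higher number a weaker inhibitor. Compound 2 holds the highest of the two numbers, with compound 1 the nearer at a lower number, but the gap between the two values falls within the usual scatter of the measurement, so neither compound can be called the stronger one. Compound 1 and compound 2 differ in two places at once, on the amide-type nitrogen and on the phenoxy ring, so their values by themselves do not separate the two changes.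

Compound 3, `CCCCCNC(=O)NS(=O)(=O)c1cc(C#N)ccc1Oc1ccc(F)cc1`, is not yet measured. It differs from compound 2 in one place: pentyl in place of tert-butyl on an amide-type nitrogen. For the measured compounds named here, the pentyl chain of compound 3 is the one found in compound 1, while the phenoxy ring is that of compound 2. Going by the values given here, with no single-change step between measured compounds to lean on, the expected step from compound 2 to compound 3 is a small one, a 1.6-fold lower number from compound 2 to compound 3 (0.19 log units; within the scatter), toward a slightly lower number but not clearly beyond the scatter. On this basis compound 3 is estimated at 2800 nM in this assay, within a range of 1000 nM to 8000 nM.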

Compound 3, half-maximal inhibitory concentration: 9430 nM
The estimate for compound 3 lay 3.4-fold (0.53 log units) below the measured number, and the stated range ends below it.
By their numbers in this assay, from the lowest: compounds 1 and 2 (each within the scatter of the next); then compound 3.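

In this assay, with the 4-fluorophenyl ring held fixed, pentyl in place of tert-butyl on the amide-type nitrogen gives a 2.2-fold higher number from compound 2 to compound 3 (0.34 log units; beyond the scatter), so this nitrogen substituent does affect the number, and the straight chain is the weaker of the two here. With the pentyl chain held fixed, 4-fluorophenyl in place of 2-methylphenyl on the oxygen gives a 4.2-fold higher number from compound 1 to compound 3 (0.62 log units; beyond the scatter), which shows that the ring also matters and separates the two changes that compounds 1 and 2 carried together. The compounds shown offer no measured reason for either step.

On these data alone, it remains open whether the effect of the chain depends on the ring, since the pentyl step is known only with 4-fluorophenyl and the ring step only with pentyl. As far as these compounds go, how a shorter propyl chain or a cyclohexyl group on that nitrogen would compare with pentyl and tert-butyl is also open, as is whether an unsubstituted phenyl or a 2-chlorophenyl ring on the oxygen would fall nearer to 2-methylphenyl or to 4-fluorophenyl.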